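This account rests on a few compounds, and the source may have more. Where it says the series, first, only, none or still open, it means among the compounds named here.

Measured compounds:
compound 1, `Nc1nc(-c2ccccn2)nn1-c1ncnc2ccccc12` — in an assay on MCF7 cells for inhibition of Serine-protein kinase ATM (Homo sapiens), read by immunofluorescence, with a stated time of 1 h (a lower number here means a stronger inhibitor, a higher number a weaker inhibitor), compound 1 gives > 40000 nM, which is a limit of the assay and not a number.
compound 2, `CCOC(=O)CNc1nc(-n2nc(-c3ccccn3)nc2N)c2cc(OC)c(OC)cc2n1` — in this assay compound 2 gives > 40000 nM, again a limit of the assay rather than a number.

Compound 2 therefore stands nowhere on a scale of numbers: it sits at the limit of > 40000 nM in this assay, at which 2 of the 2 values shown sit, and so does compound 1, so the two cannot be ordered against each other. Going by the values given here, compounds 1 and 2 differ in more than one place, so no single step between measured compounds can be read from them.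

Compound 3, `COc1cc2nc(N)nc(-n3nc(-c4ccccn4)nc3N)c2cc1OC`, differs from compound 2 in one place: hydrogen in place of (ethoxycarbonyl)methyl on a nitrogen on an aromatic ring. Nothing measured in this series bears on that change, and both anchors are limits. The working expectation is that compound 3 stays at or near the limit, with no step beyond the scatter resolvable from compound 2; the expected step is a number no higher from compound 2 to compound 3 (the limit leaves the size open). For compound 3 the estimated value in this assay is 40000 nM, expected to lie between 8000 nM and 200000 nM, most likely reported again only as a limit.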

Compound 3, half-maximal inhibitory concentration in the Serine-protein kinase ATM assay: 2100 nM
For compound 3 the middle estimate is 19-fold (1.28 log units) above the measured one; measured number outside the range, below it.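

On this nitrogen on an aromatic ring, the group present determines whether a number can be read at all: in the Serine-protein kinase ATM assay, hydrogen in place of (ethoxycarbonyl)methyl gives an at least 19-fold lower number from compound 2 to compound 3 (1.27 log units; beyond the scatter), and compound 3 is the only one of the three shown with a value that is not a limit. On these data alone, the size of that step stays open at one end, since in the Serine-protein kinase ATM assay compound 2 gives > 40000 nM, a limit of the assay and not a number: the limit of > 40000 nM in the Serine-protein kinase ATM assay, at which 2 of the 3 values shown sit. In a physicochemical assay for solubility, in phosphate buffer, with a stated time of 18 h, at pH 7.4 (a lower number here means a less soluble compound, a higher number a more soluble compound), compound 2 gives 48000 nM and compound 3 gives 27000 nM. In the physicochemical assay the same change gives a 1.8-fold lower number from compound 2 to compound 3 (0.25 log units; within the scatter), so compound 2 and compound 3 cannot be told apart in that read-out.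

The compounds shown leave open how far this nitrogen tolerates substitution, since it remains unknown how a methyl group, a longer alkyl chain, or a carboxylic acid in place of the ethyl ester would read. As far as these compounds go, no single step can be read between compound 1 and either of the other two, so the part played by the rest of the core also remains open.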